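The source may report more compounds than this note shows. Statements on the series, on what has been measured and on what is new or still open speak of the compounds shown alone.

Of the compounds shown here, three sharing one core have been measured in a functional assay (trachea) for inhibition, with Cavia porcellus as the target; a lower number here means a stronger inhibitor, a higher number a weaker inhibitor. Compound 1 (`CC1(C)C=C(N2CCCCC2=O)c2cc([N+](=O)[O-])ccc21`) gives 2240 nM, compound 2 (`CC1(C)C=C(n2ccccc2=O)c2cc([N+](=O)[O-])ccc21`) gives 840 nM, and compound 3 (`CC1(C)C=C(n2ccccc2=O)c2cc(C#N)ccc21`) gives 5260 nM. Compound 2 thus holds the lowest number of the three, and its gaps to both others lie beyond the scatter.

Compound 4 (`C[C@@H]1CCC(=O)N1C1=CC(C)(C)c2ccc([N+](=O)[O-])cc21`) keeps the nitro group of compound 2 and differs in the group on the double-bonded ring carbon: a group of 7 heavy atoms (5 carbon, 1 nitrogen, 1 oxygen; one five-membered non-aromatic ring with 1 hetero atom) in place of a group of 7 heavy atoms (5 carbon, 1 nitrogen, 1 oxygen; one six-membered aromatic ring with 1 hetero atom), on a double-bonded ring carbon. The closest measured change is a 2.7-fold lower number from compound 1 to compound 2 (0.43 log units; beyond the scatter), where a six-membered aromatic ring with 1 hetero atom took the place of a six-membered non-aromatic ring with 1 hetero atom. Within the data shown here, compound 4 moves the opposite way, from aromatic to non-aromatic, but its ring is five-membered, and no measured compound carries such a ring. The other measured change, a 6.3-fold higher number from compound 2 to compound 3 (0.80 log units; beyond the scatter), is cyano in place of nitro, a group that stays the same here, so it bears on this comparison very little.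

A modest rise in this assay is therefore expected, close in size to the first change but uncertain. The expected change is a 2.1-fold higher number from compound 2 to compound 4 (0.33 log units; beyond the scatter). Compound 4 is estimated at 1800 nM, within a range of 500 nM to 6000 nM.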

Compound 4, half-maximal inhibitory concentration: 2420 nM
Compound 4: the middle estimate sits 1.3-fold (0.13 log units) below what was measured, within the range that was stated.
By their numbers in this assay, from the lowest: compound 2; then compounds 1 and 4 (each within the scatter of the next); then compound 3.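

On the double-bonded ring carbon in this assay, the group with a five-membered non-aromatic ring gives a 2.9-fold higher number from compound 2 to compound 4 (0.46 log units; beyond the scatter), so a second non-aromatic ring, of a different size from that of compound 1, also stands apart from the six-membered aromatic ring of compound 2. Ring size among the non-aromatic groups makes no difference that can be read here, as the comparison gives a 1.1-fold higher number from compound 1 to compound 4 (0.03 log units; within the scatter), and with the nitro group kept, the aromatic ring of compound 2 holds the lowest number of the three, although compound 3 carries the same ring with cyano in place of nitro and has the highest number of all. No measurement shown accounts for the gap between the aromatic and non-aromatic groups.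

What the compounds shown leave open is how much of the value of compound 4 belongs to its ring and how much to its methyl group and defined stereocentre, which the opposite stereocentre or the same ring without the methyl group would separate. Also open, as far as these compounds go, are groups other than rings at this place, such as an open-chain acetamide or a simple amine, and whether cyano in place of nitro would shift compound 4 as it shifts compound 2.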